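Aryl change from compound 3 to compound 4

The source may hold more compounds than are shown below. What is called first, only, known or untested is meant among the compounds shown, and "the series" means these compounds.

In a functional assay on OVCAR-3 cells (Homo sapiens) for inhibition, read by MTT assay, with a stated time of 24 h (on this read-out lower numbers stand for stronger inhibition and higher numbers for weaker inhibition), compound 3 `Cc1ccccc1-n1cc(CN2C(=O)C[C@@H]3CC[C@@]2(C)C3(C)C)nn1` gives 150 nM, within the scatter of both compound 1 `CC1(C)[C@H]2CC[C@]1(C)N(Cc1cn(-c3cccc(C#N)c3)nn1)C(=O)C2` at 230 nM and compound 2 `CC1(C)[C@H]2CC[C@]1(C)N(Cc1cn(-c3ccccc3O)nn1)C(=O)C2` at 90 nM. Compound 4 `CC1(C)[C@H]2CC[C@]1(C)N(Cc1cn(-c3ccc(Cl)cc3)nn1)C(=O)C2` carries 4-chlorophenyl in place of 2-methylphenyl on an aromatic nitrogen. Within the data shown here, no measured compound bears 4-chlorophenyl, so the three measured steps offer only a general guide to size. Two of them, a 1.5-fold lower number from compound 1 to compound 3 (0.19 log units; within the scatter) and a 1.7-fold higher number from compound 2 to compound 3 (0.22 log units; within the scatter), stay within the scatter, while the largest, a 2.6-fold lower number from compound 1 to compound 2 (0.41 log units; beyond the scatter), is modest. The expected result is a 1.1-fold higher number from compound 3 to compound 4 (0.03 log units; within the scatter), with no step beyond the scatter. The estimated value for compound 4 is 160 nM, with an expected range of 70 nM to 350 nM.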

Compound 4, half-maximal inhibitory concentration: 160 nM
Estimate against measurement, compound 4: no gap at the digits printed; measured number inside the range.
By their numbers in this assay, from the lowest: compounds 2, 3, 4 and 1 (each within the scatter of the next, the first and the last beyond it).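

In this assay the step of a 1.1-fold higher number from compound 3 to compound 4 (0.03 log units; within the scatter) and the step of a 1.8-fold higher number from compound 2 to compound 4 (0.25 log units; within the scatter) and the step of a 1.4-fold lower number from compound 1 to compound 4 (0.16 log units; within the scatter) all stay within the scatter. A chlorine-bearing aryl group on this aromatic nitrogen is therefore not separated from any of the three earlier aryl groups, even though compound 1 and compound 2 are separated from each other. No evidence at hand accounts for this result.

Open, going by these compounds, is whether an aminophenyl or carboxyphenyl group at this nitrogen would leave the number within the scatter. Also open, on these data alone, is how a longer chain such as benzyl or phenethyl would behave there.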